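The source may report more compounds than this note shows. Statements on the series, on what has been measured and on what is new or still open speak of the compounds shown alone.

Working notes on the series. For the measured compounds named here, compound 1 `Cc1ccccc1-n1c(Nc2nc(-c3ccc([N+](=O)[O-])cc3)cs2)n[nH]c1=S` and compound 2 `COc1ccc(-n2c(Nc3nc(-c4ccc(Cl)cc4)cs3)n[nH]c2=S)cc1` share the core and differ in two places at once, so no single-change step between them can be stated. In a functional assay on the whole organism (strain Swiss albino) for inhibition, with Mus musculus as the target, with a stated time of 0.5 h (on this read-out higher numbers stand for an effect only at larger amounts of compound and lower numbers for an effect already at smaller amounts), compound 1 gives 100 mg/kg and compound 2 gives 300 mg/kg. Compound 2 thus holds the higher of the two numbers on record, and the gap to compound 1 lies beyond the scatter.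

Compound 3 `COc1ccccc1-n1c(Nc2nc(-c3ccc(Cl)cc3)cs2)n[nH]c1=S` is not yet measured; it differs from compound 2 only by 2-methoxyphenyl in place of 4-methoxyphenyl on an aromatic nitrogen. The two measured values give no guide to this change, so the expected step of a 1.5-fold lower number from compound 2 to compound 3 (0.18 log units; within the scatter) is small and not clearly beyond the scatter. Compound 3 is estimated at 200 mg/kg, within 100 mg/kg to 400 mg/kg.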

Compound 3, minimum effective dose: 100 mg/kg
Compound 3: the middle estimate sits 2.0-fold (0.30 log units) above what was measured; measured number inside the range.
By their numbers in this assay, from the lowest: compounds 1 and 3 (each within the scatter of the next); then compound 2.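

With the same atoms joined differently, 2-methoxyphenyl in place of 4-methoxyphenyl on the aromatic nitrogen gives a 3.0-fold lower number from compound 2 to compound 3 (0.48 log units; beyond the scatter), so the number in this series depends on where the methoxy group sits on this phenyl ring. Compounds 1 and 2 differ in two places at once and could not show this. Nothing on hand accounts for the step.

From the compounds shown here alone, whether the change gives the same step with a nitro group in place of the chlorine stays open. So does the effect of an amine or a carboxylic acid in place of the methoxy group.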